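The source may hold more compounds than are shown below. What is called first, only, known or untested is meant among the compounds shown, and "the series" means these compounds.

Measured in a functional assay on MGC-803 cells (Homo sapiens) for antiproliferative activity, read by MTT assay, with a stated time of 72 h; a higher number here means a weaker inhibitor, a lower number a stronger inhibitor:
compound 1 `Cc1cccc(-c2nc(CNc3ccc(C(=O)NO)cc3)n(-c3ccccc3)n2)c1`: 8710 nM
compound 2 `Cc1ccccc1-n1nc(-c2ccccc2)nc1CNc1ccc(C(=O)NO)cc1`: 12300 nM
compound 3 `COc1ccc(-n2nc(-c3ccccc3)nc2CNc2ccc(C(=O)NO)cc2)cc1`: 7050 nM

Compound 1 stands second highest of the three numbers; its gaps to compound 3 and to compound 2 are both within the scatter, so no order among the three is claimed. Among the measured compounds shown here, the only step measured in one place is a 1.7-fold lower number from compound 2 to compound 3 (0.24 log units; within the scatter), a change of the group on the aromatic nitrogen, and it stays within the scatter.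

Compound 4 `Cc1ccc(-c2nc(CNc3ccc(C(=O)NO)cc3)n(-c3ccccc3)n2)s1` differs from compound 1 by 5-methylthiophen-2-yl in place of 3-methylphenyl on an aromatic carbon. For the measured compounds named here, no measured step touches this position, so nothing here predicts a shift beyond the scatter, and the range is kept wide. Compound 4 is expected near 8000 nM, between 3500 nM and 18000 nM. The expected step is a 1.1-fold lower number from compound 1 to compound 4 (0.04 log units; within the scatter).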

Compound 4, half-maximal inhibitory concentration: 8450 nM
Compound 4: the middle estimate sits 1.1-fold (0.02 log units) below what was measured; the range from low to high includes it.
By their numbers in this assay, from the lowest: compounds 3, 4, 1 and 2 (each within the scatter of the next).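

On the aromatic carbon between two ring nitrogen atoms, 5-methylthiophen-2-yl in place of 3-methylphenyl gives a 1.0-fold lower number from compound 1 to compound 4 (0.01 log units; within the scatter) in this assay. Among the compounds shown here, this is the first step read at this position, and it shows that a five-membered aromatic ring with a sulfur atom can stand in place of the six-membered carbon ring without a step beyond the scatter. No available evidence gives a reason for this result.

Going by these compounds, whether this position responds to any change remains open, since both groups are methyl-bearing aromatic rings. An amine or a carboxylic acid on this carbon would test that.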